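Fluoro for Methyl Repeated on a Second Core

The source may hold more compounds than are shown below. What is called first, only, known or untested is meant among the compounds shown, and "the series" means these compounds.

compound 1 | `Cc1ccc(-c2ccc(C)n2-c2ccc(-c3nc4ccccc4s3)cc2)cc1` | 2500 nM
compound 2 | `Cc1ccc(-c2ccc(F)cc2)n1-c1ccc(-c2nc3ccccc3s2)cc1` | 2620 nM
compound 3 | `COc1ccc2nc(-c3ccc(-n4c(C)ccc4-c4ccc(C)cc4)cc3)sc2c1` | 2570 nM

Of the compounds shown here, three have been measured in a functional assay on MCF7 cells (Homo sapiens) for cytotoxicity, read by sulforhodamine B assay, with a stated time of 48 h (on this read-out lower numbers stand for stronger inhibition of growth and higher numbers for weaker inhibition of growth), and their three numbers lie within the scatter of one another. Compound 2 differs from compound 1 by fluoro in place of methyl on an aromatic carbon, and the measured step is a 1.0-fold higher number from compound 1 to compound 2 (0.02 log units; within the scatter). Compound 3 differs from compound 1 in its core, by methoxy in place of hydrogen on an aromatic carbon, and the step there is a 1.0-fold higher number from compound 1 to compound 3 (0.01 log units; within the scatter). Compound 4 `COc1ccc2nc(-c3ccc(-n4c(C)ccc4-c4ccc(F)cc4)cc3)sc2c1` has not been measured. It differs from compound 3 by fluoro in place of methyl on an aromatic carbon. The surroundings of the place are described in the same words for both pairs, so this is the same change, made twice among these four compounds, once on each core. In this assay the expected step is a 1.0-fold higher number from compound 3 to compound 4 (0.01 log units; within the scatter), because the same change on the other core gave a 1.0-fold higher number from compound 1 to compound 2 (0.02 log units; within the scatter). Compound 4 is therefore estimated at 2600 nM, with an expected range from 1300 nM to 5200 nM.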

Compound 4, concentration for 50% growth inhibition: 2480 nM
The estimate for compound 4 lay 1.0-fold (0.02 log units) above the measured number; the range from low to high includes it.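

In this assay, fluoro in place of methyl gave a 1.0-fold lower number from compound 3 to compound 4 (0.02 log units; within the scatter), and this step could not be told apart from the one on the core of compound 1: the same change on two cores in this assay, a 1.0-fold higher number (0.02 log units; within the scatter) from compound 1 to compound 2 and a 1.0-fold lower number (0.02 log units; within the scatter) from compound 3 to compound 4, 1.1-fold (0.04 log units) apart, within the scatter of two such steps. Methoxy in place of hydrogen, read on the pair carrying fluoro, gave a 1.1-fold lower number from compound 2 to compound 4 (0.02 log units; within the scatter), and it agreed in the same way with its earlier step: the same change on two cores in this assay, a 1.0-fold higher number (0.01 log units; within the scatter) from compound 1 to compound 3 and a 1.1-fold lower number (0.02 log units; within the scatter) from compound 2 to compound 4, 1.1-fold (0.04 log units) apart, within the scatter of two such steps. The two changes thus left the number within the scatter on both cores, but with steps this small the agreement does not show that a step of real size would carry from one core to another.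

The compounds shown leave open whether a group such as an amine, a carboxylic acid or a longer chain in the place of the fluoro would move the number beyond the scatter, and whether such a step would then repeat on both cores. They also leave open whether the agreement seen here would hold on a third core.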